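A few compounds are considered here, and "the series" means these few. Any claim that something is new, unique, unknown or untested is made for them only; others in the source may bear on it.

Of the compounds shown here, three have numbers so far in a functional assay on HEK-293T cells (Homo sapiens) for cytotoxicity, read by MTT assay; a higher number here means that more compound is tolerated, a lower number that less compound is tolerated. Compound 1 `COc1ccc(-c2nc3ccccn3c2Nc2cc(OC)c(OC)c(OC)c2)cc1O` gives 10000 nM and compound 2 `COc1cc(Nc2c(C3C=Nc4ccccc43)nc3cnccn23)cc(OC)c1OC` gives 12000 nM while compound 3 `COc1ccc(Nc2c(-c3ccc(OC)cc3)nc3ccccn23)cc1` gives 34000 nM as the highest number of the three, beyond the scatter from both of the others. Compound 4 `COc1ccc(Nc2c(-c3cccc(O)c3)nc3ccccn23)cc1` has no number yet and differs from compound 3 in one place, with 3-hydroxyphenyl in place of 4-methoxyphenyl on an aromatic carbon as the change. Among the compounds with values here, no measured pair differing in one place offers a guide. Compound 1 also carries a hydroxy group and gives 10000 nM so a modest move to a lower number is expected, only a little beyond the scatter. The estimate is a step of a 2.3-fold lower number from compound 3 to compound 4 (0.36 log units; beyond the scatter) of that modest size. Compound 4 is expected at 15000 nM (estimated range 6000 nM to 40000 nM).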

Compound 4, concentration lethal to 50% of the cells: 47000 nM
The estimate for compound 4 lay 3.1-fold (0.50 log units) below the measured number; the measured number lies above the stated range.
By their numbers in this assay, from the lowest: compounds 1 and 2 (each within the scatter of the next); then compounds 3 and 4 (each within the scatter of the next).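

In this assay, 3-hydroxyphenyl in place of 4-methoxyphenyl on an aromatic carbon gives a 1.4-fold higher number from compound 3 to compound 4 (0.14 log units; within the scatter). Within the data shown here, this is the first step that can be read at this position, and it shows that this swap, which adds a hydrogen-bond donor, leaves the number unchanged within the usual spread of repeat measurements. No measured evidence bears on this result. The compounds shown leave open what 3-methoxyphenyl or 4-hydroxyphenyl would give, so the group and its ring position cannot be separated. They also leave open whether an amine or a carboxylic acid in place of the hydroxy group would move the number beyond the scatter.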